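Swapping One Benzyl Group on a Shared Sulfonamide Scaffold

This account rests on a few compounds, and the source may have more. Where it says the series, first, only, none or still open, it means among the compounds named here.

Compound 1 `Cc1ccc(S(=O)(=O)N(Cc2cn(Cc3ccccc3Cl)nn2)Cc2cn(S(=O)(=O)c3ccc(C)cc3)c3ccccc23)cc1` was tested in a functional assay on 3T3-L1 cells (Mus musculus) for inhibition, with a stated time of 20 min, tested at 20 uM (a higher number here means more inhibition at the concentration tested (going by the name of the read-out), a lower number less inhibition), where compound 1 gives -4.8%. That is the top number among the three measured compounds, but only just: compound 2 `COc1cc(Cn2cc(CN(Cc3c(-c4ccccc4)c4ccccc4n3S(=O)(=O)c3ccc(C)cc3)S(=O)(=O)c3ccc(C)cc3)nn2)cc(OC)c1OC` gives -10.9% in this assay, and the gap between the two lies within the usual scatter, so they cannot be told apart. Compound 3 `O=C(N(Cc1ccc(F)cc1)Cc1cccc(F)c1F)C(F)(F)F`, a much smaller molecule of quite different build, gives -39.8% in this assay, a gap from compound 1 that lies beyond the scatter.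

Compound 4 `COc1ccc(Cn2cc(CN(Cc3cn(S(=O)(=O)c4ccc(C)cc4)c4ccccc34)S(=O)(=O)c3ccc(C)cc3)nn2)cc1` has not yet been measured. It differs from compound 1 in one place: 4-methoxyphenyl in place of 2-chlorophenyl on a saturated chain carbon bound to an aromatic nitrogen. Among the measured compounds shown here, no measured pair shows the effect of this exact change. Compounds 1 and 2 are built alike and carry different groups on the same chain carbon, yet their numbers sit within the scatter of each other. The step from compound 1 to compound 4 is therefore expected to be a number 2.2 percentage points lower from compound 1 to compound 4 (within the scatter), none beyond the scatter, because compound 2 gives -10.9% despite its own different group there. Compound 4 is estimated to give -7% in this assay, within a range from -22% to 8%.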

Compound 4, a percentage reported as inhibition, at one concentration (the size of the read-out at that concentration, not a potency): 1%
Beside the measured number, compound 4's estimate is 8 percentage points below it, within the range that was stated.
By their numbers in this assay, from the lowest: compound 3; then compounds 2, 1 and 4 (each within the scatter of the next, the first and the last beyond it).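

Among the compounds shown here, this is the first direct reading at this position: with the rest of compound 1 unchanged, putting 4-methoxyphenyl in place of 2-chlorophenyl on a saturated chain carbon bound to an aromatic nitrogen gives a number 5.8 percentage points higher from compound 1 to compound 4 (within the scatter) in this assay. The swap changes the ring's substituent and adds one hydrogen-bond acceptor by count, yet the two compounds cannot be told apart at the single concentration tested. Nothing measured here explains this lack of a clear difference. On these data alone, it remains open whether any group at this position can move the read-out beyond the scatter, such as a phenyl ring carrying a carboxylic acid or an amine. A single pair also cannot show whether this holds on other cores.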